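This account rests on a few compounds, and the source may have more. Where it says the series, first, only, none or still open, it means among the compounds named here.

Three compounds have been measured in an assay on CHO cells for displacement of a labelled ligand from melatonin receptor type 1B (Homo sapiens), read by scintillation counting, with a stated time of 60 min; on this read-out lower numbers stand for stronger inhibition and higher numbers for weaker inhibition:

compound 1, `CCOc1ccc(OC)cc1CCCNC(C)=O`, gives 1.59 nM
compound 2, `CCCOc1ccc(OC)cc1CCCNC(C)=O`, gives 2.12 nM
compound 3, `COc1cc(CCCNC(C)=O)ccc1OCc1ccccc1`, gives 69.3 nM

Compound 1 and compound 2 differ in one place: methyl in place of hydrogen on a saturated chain carbon, two bonds along the chain from an oxygen on an aromatic ring. This change made a step of a 1.3-fold higher number from compound 1 to compound 2 (0.12 log units; within the scatter), so the two compounds cannot be told apart in this assay. Compound 3 sits well apart from both: against compound 2 its number is higher by a wide margin, and against compound 1 by a still wider one, both clearly beyond the scatter. How the core of compound 3 differs from the core of compound 1 is not broken down here.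

Compound 4, `CCC(=O)NCCCc1ccc(OCc2ccccc2)c(OC)c1`, has not yet been measured. It differs from compound 3 in one place: methyl in place of hydrogen on a saturated chain carbon bound to a carbonyl carbon. For the measured compounds named here, this is the same kind of change as the one from compound 1 to compound 2, a methyl in place of hydrogen, but at a different place: there the carbon was two bonds along the chain from an oxygen on an aromatic ring, here it is bound to a carbonyl carbon. Going by the values given here, the only measured example of a single added methyl, the step of a 1.3-fold higher number from compound 1 to compound 2 (0.12 log units; within the scatter), stayed within the scatter, and nothing in the data says that the change at this new place behaves any differently. The step from compound 3 to compound 4 is therefore expected to be small, around a 1.4-fold lower number from compound 3 to compound 4 (0.14 log units; within the scatter), resting on compound 3 at 69.3 nM and on the step of a 1.3-fold higher number from compound 1 to compound 2 (0.12 log units; within the scatter). Compound 4 is accordingly estimated at 50 nM in this assay, with a plausible range from 15 nM to 160 nM.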

Compound 4, inhibition constant: 121 nM
Estimate against measurement, compound 4: 2.4-fold (0.38 log units) below; low and high end bracket the measured number.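

In this assay, the extra methyl that turns acetamido into propanoylamino gives a 1.7-fold higher number from compound 3 to compound 4 (0.24 log units; within the scatter), so this pair cannot be told apart. Set beside the earlier methyl step, the new one shows that the change stayed small on both cores, and that its size did not measurably shift from one core to the other: the same change on two cores in this assay, a 1.3-fold higher number (0.12 log units; within the scatter) from compound 1 to compound 2 and a 1.7-fold higher number (0.24 log units; within the scatter) from compound 3 to compound 4, 1.3-fold (0.12 log units) apart, within the scatter of two such steps. For the compounds shown here, this is only two steps, though, and the methyl sits at a different place in each, once on a saturated chain carbon two bonds along the chain from an oxygen on an aromatic ring and once on a saturated chain carbon bound to a carbonyl carbon, so the result supports a small step at these two places on these two cores and gives no general rule for other places or other cores.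

From the compounds shown here alone, what happens when the chain bound to the carbonyl carbon grows further remains open, for example with butanoyl or a longer chain in place of propanoyl. Going by these compounds, it is equally open whether a group of another kind at that place, such as an amine or a carboxylic acid, would leave the number as little changed as the methyl did.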